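The source may report more compounds than this note shows. Statements on the series, on what has been measured and on what is new or still open speak of the compounds shown alone.

Measured in a functional assay on MCF7 cells (Homo sapiens), with a stated time of 72 h; on this read-out higher numbers stand for weaker inhibition and lower numbers for stronger inhibition:
Compound 1 `C=CCOc1c(C)c(C)c2c(c1C)CCC(C)(COc1ccc(/C=C3\SC(=O)NC3=O)cc1)O2`: > 5000 nM, a limit of the assay.
Compound 2 `CCCCOc1c(C)c(C)c2c(c1C)CCC(C)(COc1ccc(/C=C3\SC(=O)NC3=O)cc1C(F)(F)F)O2`: 6000 nM.

Compound 1 has no number of its own in this assay. Its reading is a limit: the limit of > 5000 nM in this assay, at which 1 of the 2 values shown sits. Compound 3 `C=CCOc1c(C)c(C)c2c(c1C)CCC(C)(COc1ccc(/C=C3\SC(=O)NC3=O)cc1OC)O2` keeps the core of compound 1 and makes one change, methoxy in place of hydrogen on an aromatic carbon, ortho to a large group (methoxy in place of hydrogen on an aromatic carbon). Within the data shown here, no measured step speaks directly to this change. Among the measured compounds shown here, the only true number comes from compound 2 at 6000 nM, which differs from compound 1 in more than one place and still shows weak inhibition. On that basis, only a small shift is expected in this assay, with no firm direction and probably nothing beyond the scatter: the expected step is a number no higher from compound 1 to compound 3 (the limit leaves the size open). For compound 3 the estimated value is 5000 nM, with an expected range of 1500 nM to 15000 nM.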

Compound 3, half-maximal inhibitory concentration: 2500 nM
The estimate for compound 3 lay 2.0-fold (0.30 log units) above the measured number, and the stated range covers the measured number.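

In this assay, among these compounds, methoxy in place of hydrogen on an aromatic carbon, ortho to a large group, gives the first step that can be read at this position: an at least 2.0-fold lower number from compound 1 to compound 3 (0.30 log units; that floor lies within the scatter). With this change, compound 3 gives 2500 nM, a true number where compound 1 has none. The true size of the step stays open, and its floor does not by itself place it beyond the scatter, because the reading of compound 1 is a limit of the assay: the limit of > 5000 nM in this assay, at which 1 of the 3 values shown sits.

From the compounds shown here alone, whether a hydroxy group, an amine or a longer chain such as ethoxy on this carbon would give a number like that of compound 3 remains open. Also open, going by these compounds, is whether methoxy in this place would give a similar step with a different ether chain on the shared core.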